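Bromo for Chloro: What to Expect of Compound 4

The source may report more compounds than this note shows. Statements on the series, on what has been measured and on what is new or still open speak of the compounds shown alone.

Compound 1, `N#CC1=C(N)Oc2cc3oc(-c4ccccc4)cc(=O)c3c(O)c2C12C(=O)N(Cc1ccccc1)c1ccc(Cl)cc12`, gives > 50000 nM in a functional assay on NCI-H1299 cells (Homo sapiens) for antiproliferative activity, read by MTT assay, with a stated time of 48 h (on this read-out higher numbers stand for weaker inhibition and lower numbers for stronger inhibition), which is a limit of the assay and not a number.
Compound 2, `N#CC1=C(N)Oc2cc3oc(-c4ccccc4)cc(=O)c3c(O)c2C12C(=O)N(Cc1ccccc1)c1ccc(Br)cc12`, gives > 50000 nM in this assay, again a limit of the assay.
Among the compounds with values here, compound 3, `N#CC1=C(N)Oc2cc3oc(-c4ccccc4)cc(=O)c3c(O)c2C12C(=O)Nc1cc(Cl)ccc12`, gives 16600 nM in this assay, the only number among the three.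

Compound 1 and compound 2 differ by bromo in place of chloro on an aromatic carbon. The step that the two limits leave unreadable from compound 1 to compound 2 cannot be read, since both values sit at the limit of > 50000 nM in this assay, at which 2 of the 3 values shown sit. The difference between the core of compound 1 and the core of compound 3 is not broken down here.

Compound 4, `N#CC1=C(N)Oc2cc3oc(-c4ccccc4)cc(=O)c3c(O)c2C12C(=O)Nc1cc(Br)ccc12`, has not been measured. It differs from compound 3 by bromo in place of chloro on an aromatic carbon, and the surroundings of the place are the same as in the change from compound 1 to compound 2, so it is the same change. That earlier step gives no readable size, so the expectation rests on compound 3 alone, whose value 16600 nM is the only number shown, and on the smallness of the change. The expected step of a 1.0-fold lower number from compound 3 to compound 4 (0.02 log units; within the scatter) is therefore estimated to be small. Compound 4 is expected to give about 16000 nM, between 7000 nM and 40000 nM.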

Compound 4, half-maximal inhibitory concentration: 14400 nM
Compound 4: the middle estimate sits 1.1-fold (0.05 log units) above what was measured; the range from low to high includes it.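

In this assay, bromo in place of chloro on the core of compound 3 gives a 1.2-fold lower number from compound 3 to compound 4 (0.06 log units; within the scatter), so on this core the two halogens cannot be told apart. Within the data shown here, the same change on the core of compound 1 cannot be read, and the step on one core therefore cannot be set against the step on the other: the limit of > 50000 nM in this assay, at which 2 of the 4 values shown sit. Compound 3 and compound 4 thus form the only readable pair for this change, which shows what it does on that one core but not that a step of this size carries over to any other core.

The compounds shown leave open whether a group other than chloro or bromo at this place, such as fluoro, methoxy, an amine or a carboxylic acid, would give a number set apart from those of compound 3 and compound 4. They also leave open what the benzyl group of compound 1 and compound 2 does on its own, as no pair shown differs by that group alone.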